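Cyclobutyl carboxamide replacing oxanyl on the aminopyridine nitrogen

This account rests on a few compounds, and the source may have more. Where it says the series, first, only, none or still open, it means among the compounds named here.

Compound 2 `N#Cc1cnc(NCc2cnccc2C(F)(F)F)cc1NC1CCOCC1` stands at the highest number of the two measured in this series. In an assay on isolated protein for inhibition of protein kinase C theta type (Homo sapiens), read by TR-FRET, with a stated time of 2 h (on this read-out lower numbers stand for stronger inhibition and higher numbers for weaker inhibition), compound 2 gives 900 nM, whereas compound 1 `CO[C@H]1CC[C@@H](Nc2cc(NCc3cnccc3C(F)(F)F)ncc2C#N)CC1` gives 58 nM. Among the compounds with values here, the single measured step between them is a 16-fold higher number from compound 1 to compound 2 (1.19 log units; beyond the scatter), which shows that the group on this nitrogen moves the number substantially.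

Compound 3 `CC1(C)[C@H](Nc2cc(NCc3cnccc3C(F)(F)F)ncc2C#N)C[C@H]1C(N)=O` is not yet measured. It differs from compound 2 by 3-carbamoyl-2,2-dimethylcyclobutyl in place of oxan-4-yl on a nitrogen on an aromatic ring. Within the data shown here, the only step that bears on this change is the one from compound 1 to compound 2, since it alters the same position; its size was a 16-fold higher number from compound 1 to compound 2 (1.19 log units; beyond the scatter). Among the measured compounds shown here, no measured pair shows the 3-carbamoyl-2,2-dimethylcyclobutyl group itself, so the direction of the next step cannot be read from the data. A step well beyond the scatter is plausible in either direction. On balance, compound 3 is expected to give a somewhat lower number than compound 2, estimated as 300 nM, with a range of 60 nM to 1500 nM. The step this estimate implies is a 3.0-fold lower number from compound 2 to compound 3 (0.48 log units; beyond the scatter), which is offered as an expectation only.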

Compound 3, half-maximal inhibitory concentration: 140 nM
Compound 3: the middle estimate sits 2.1-fold (0.33 log units) above what was measured, within the range that was stated.
By their numbers in this assay, from the lowest: compound 1; then compound 3; then compound 2.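

Working notes on the nitrogen substituent: in this assay the step of a 6.4-fold lower number from compound 2 to compound 3 (0.81 log units; beyond the scatter) shows that the number at this position can be brought down without a six-membered ring, since 3-carbamoyl-2,2-dimethylcyclobutyl, with its four-membered ring of carbon only, enters here in place of oxan-4-yl. The comparison with the other six-membered substituent runs the opposite way, with a 2.4-fold higher number from compound 1 to compound 3 (0.38 log units; beyond the scatter) still beyond the scatter, so 4-methoxycyclohexyl keeps the lowest number of the three and the new group recovers only part of the gap opened by oxan-4-yl. No measurement available here gives a reason for either step.

The ring size, the two methyl groups, the carbamoyl group and the defined stereocentres all change together in compound 3, so the share of each in the step remains unresolved. An unsubstituted cyclobutyl, a 2,2-dimethylcyclobutyl without the carbamoyl group, a carboxylic acid or a primary amine in place of the carbamoyl group, or the other stereoisomers of compound 3 would be needed to separate these contributions.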